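The source may report more compounds than this note shows. Statements on the series, on what has been measured and on what is new or still open speak of the compounds shown alone.

Compound 1, `CCNCc1cc(Cl)cc(Nc2nc3ccccc3n2Cc2ccc(C(F)(F)F)cc2)c1O`: 33800 nM
Compound 2, `Cc1cc(CNC(C)(C)C)c(O)c(Nc2nc3cc(F)c(F)cc3[nH]2)c1`: 16700 nM
Compound 3, `Cc1cc(CNC(C)(C)C)c(O)c(Nc2nc3cc(F)c(F)cc3n2Cc2ccc(C(F)(F)F)cc2)c1`: 10000 nM

In an ADME assay on CHO cells (Cricetulus griseus) for inhibition, read by MTT assay (a higher number here means a weaker inhibitor, a lower number a stronger inhibitor), compound 1 gives 33800 nM, the highest of the three numbers, and compound 2 stands nearest to it. Compounds 2 and 3 share one core, and the step of a 1.7-fold higher number from compound 3 to compound 2 (0.22 log units; within the scatter) corresponds to the change (hydrogen in place of 4-(trifluoromethyl)benzyl on an aromatic nitrogen). Compound 4, `CCNCc1cc(Cl)cc(Nc2nc3ccccc3[nH]2)c1O`, has not yet been measured in this assay; it arises from compound 1 by the same change, (hydrogen in place of 4-(trifluoromethyl)benzyl on an aromatic nitrogen), the place of the change being the same in both pairs. The difference between the core of compound 1 and the core of compound 3 is not broken down here, so the expectation for compound 4 rests on one earlier step only. Because the step of a 1.7-fold higher number from compound 3 to compound 2 (0.22 log units; within the scatter) stayed within the scatter, compound 4 is expected to come out close to compound 1, with a slight lean toward a higher number. Compound 4 is therefore expected to give about 50000 nM, with a likely range from 20000 nM to 120000 nM. That estimate for compound 4 means an expected step of a 1.5-fold higher number from compound 1 to compound 4 (0.17 log units; within the scatter).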

Compound 4, half-maximal inhibitory concentration: > 50000 nM
Compound 4 ended at the assay's limit; the forecaster's own chance of this, stated with the estimate: 25%; the middle value lies on the limit itself.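

In this assay compound 4 reads > 50000 nM, which is a limit of the assay and not a number. On the core of compound 1, hydrogen in place of 4-(trifluoromethyl)benzyl on the aromatic nitrogen gives an at least 1.4-fold higher number from compound 1 to compound 4 (0.17 log units; that floor lies within the scatter), and this figure is only a floor for the step, not its size. The result therefore fits the change carrying over from one core to the other, but it does not show that the change has the same size on both, and two cores are too few to support a rule for the series: the same change on two cores in this assay, a 1.7-fold higher number (0.22 log units; within the scatter) from compound 3 to compound 2 and an at least 1.4-fold higher number (0.17 log units; that floor lies within the scatter) from compound 1 to compound 4; the limit leaves it open whether they differ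

On these data alone, the true size of the step on the core of compound 1 remains open, as compound 4 gives only a limit. As far as these compounds go, it is also open how this assay would respond to other groups on that aromatic nitrogen, such as a methyl group or an unsubstituted benzyl, on either core.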